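This account rests on a few compounds, and the source may have more. Where it says the series, first, only, none or still open, it means among the compounds named here.

Series notes. Compound 1 `CC(=O)Oc1ccccc1C(=O)OCC[Se]C#N` is the starting point. In a functional assay on MDA-MB-231 cells (Homo sapiens) for antiproliferative activity, read by MTT assay, with a stated time of 24 h (a lower number here means a stronger inhibitor, a higher number a weaker inhibitor), compound 1 gives > 50000 nM, a limit of the assay rather than a number. Compound 2 `CC(=O)Oc1ccccc1C(=O)[Se]CC[Se]C#N` carries a different group on the carbonyl carbon. In this assay compound 2 gives > 50000 nM, again a limit of the assay. The step that the two limits leave unreadable from compound 1 to compound 2 is therefore unreadable, both ends sitting at the limit; the limit of > 50000 nM in this assay, at which 2 of the 2 values shown sit, summarises where the measured values stand. Compound 2 thus stands at the limit, with no number to place it on.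

Compound 3 `CC(=O)Oc1ccccc1C(=O)NCCSC#N` is not yet measured. It differs from compound 2 in a group of 6 heavy atoms (3 carbon, 2 nitrogen, 1 sulfur; no ring) in place of a group of 6 heavy atoms (3 carbon, 1 nitrogen, 2 selenium; no ring), on a carbonyl carbon. Among the compounds with values here, no measured step bears on this change, since the only step available is unreadable. For compound 3 in this assay a value of 60000 nM is expected, with a range from 20000 nM to 200000 nM, most likely reported only as a limit. The expected step that the limit leaves unreadable from compound 2 to compound 3 is accordingly not readable as a size beyond the scatter.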

Compound 3, half-maximal inhibitory concentration: > 50000 nM
Compound 3 was reported as a limit; the forecaster's own chance of this, stated with the estimate: 80%; the middle value lies beyond the limit too.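

Compound 3 also stands at a limit in this assay, so no step among compound 1, compound 2 and compound 3 can be read: the limit of > 50000 nM in this assay, at which 3 of the 3 values shown sit.

The compounds shown leave open how the group on the carbonyl carbon affects activity, with none of them giving a number to compare.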